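Swapping the Ester Arm for an Oxadiazole Ring

A few compounds are considered here, and "the series" means these few. Any claim that something is new, unique, unknown or untested is made for them only; others in the source may bear on it.

Compound 1 `CCOC(=O)CN(c1ccccc1)C1c2cc(C#N)ccc2OC(C)(C)C1O` gives > 30000 nM in a functional assay (aorta) with Rattus norvegicus as the target; on this read-out lower numbers stand for stronger inhibition and higher numbers for weaker inhibition.
Compound 2 `CCOC(=O)CN(c1ccccc1)[C@H]1c2cc(C#N)ccc2OC(C)(C)[C@@H]1O` gives > 30000 nM in this assay.
Compound 3 `CCOC(=O)CN(c1nc2ccccc2o1)[C@H]1c2cc(C#N)ccc2OC(C)(C)[C@@H]1O` gives > 30000 nM in this assay.

Each of these three values is a limit of the assay, not a measured number. Compound 2 therefore stands only at a limit, and so do the two compounds around it. The step that the two limits leave unreadable from compound 1 to compound 2 cannot be read in size because of the limit of > 30000 nM in this assay, at which 3 of the 3 values shown sit, and the same holds for a step that the two limits leave unreadable from compound 2 to compound 3. The step the fact that one of compounds 1 and 2 is drawn with a defined configuration and the other without, at the place where they differ adds nothing readable either.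

Compound 4 `Cc1noc(CN(c2ccccc2)[C@H]2c3cc(C#N)ccc3OC(C)(C)[C@@H]2O)n1` differs from compound 2 in one place: 3-methyl-1,2,4-oxadiazol-5-yl in place of ethoxycarbonyl on a saturated chain carbon bound to a nitrogen on an aromatic ring. Going by the values given here, no measured step touches this position, so there is nothing that points to a direction for the change. Among the compounds with values here, the only guidance is that every compound with this shared core so far has sat at the limit. Compound 4 is therefore expected to sit at the limit as well, with an estimated value of 30000 nM and a range from 10000 nM to 100000 nM. The expected step is a number no higher from compound 2 to compound 4 (the limit leaves the size open), which means no change beyond the scatter.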

Compound 4, half-maximal inhibitory concentration: > 30000 nM
Compound 4: no number, only a limit; the forecaster's own chance of this, stated with the estimate: 85%; the middle value sits exactly at the limit.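

In this assay compound 4 gives > 30000 nM, which is a limit and not a number. Compound 2 also stands only at a limit, so the step between compound 2 and compound 4 cannot be read. The compounds shown leave open whether 3-methyl-1,2,4-oxadiazol-5-yl in place of ethoxycarbonyl changes inhibition at all.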